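From Bromomethyl to a Selenium Group

The compounds below may be only part of what the source reports. "The series", "measured", "known", "first", "only" and "open" are said of these compounds alone.

Within the data shown here, in a functional assay on HeLa cells (Homo sapiens) for antiproliferative activity, read by MTT assay, with a stated time of 48 h (on this read-out higher numbers stand for weaker inhibition and lower numbers for stronger inhibition), compound 1 `COc1ccc(N(C)c2ccnc(Cl)n2)cc1[N+](=O)[O-]` gives 4730 nM and compound 2 `COc1ccc(N(C)c2ccnc(Cl)n2)cc1OCCCCCBr` gives 7090 nM, so compound 2 stands within the usual scatter of the only other measured number. Compound 3 `COc1ccc(N(C)c2ccnc(Cl)n2)cc1OCCCC[Se]C#N` differs from compound 2 by one change: a group of 3 heavy atoms (1 carbon, 1 nitrogen, 1 selenium; no ring) in place of a group of 2 heavy atoms (1 carbon, 1 bromine; no ring), on a saturated chain carbon, four bonds along the chain from an oxygen on an aromatic ring. A group of 3 heavy atoms (1 carbon, 1 nitrogen, 1 selenium; no ring) replaces bromomethyl, on a saturated chain carbon, four bonds along the chain from an oxygen on an aromatic ring. Among the measured compounds shown here, only one measured step is available: a 1.5-fold higher number from compound 1 to compound 2 (0.18 log units; within the scatter). For the measured compounds named here, it involves a different change, so it offers little guidance, and no measured compound carries the entering group. The expected step, judged from the structural change alone, is a 3.5-fold lower number from compound 2 to compound 3 (0.55 log units; beyond the scatter), toward stronger inhibition. For compound 3, the estimated value is 2000 nM, with an expected range of 300 nM to 7500 nM.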

Compound 3, half-maximal inhibitory concentration: > 10000 nM
Compound 3: a limit, no number (the forecaster's own chance of this, stated with the estimate: 3%); at least 5.0-fold (0.69 log units) between middle value and limit.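

In this assay compound 3 gives > 10000 nM, which is a limit of the assay and not a number. Swapping bromomethyl for the selenium group at this chain end brings no stronger inhibition, with an at least 1.4-fold higher number from compound 2 to compound 3 (0.14 log units; that floor lies within the scatter), although that floor on its own lies within the scatter. Among these compounds, replacing nitro with the whole selenium-bearing chain, on an aromatic carbon, gives an at least 2.1-fold higher number from compound 1 to compound 3 (0.32 log units; beyond the scatter), the first step in this set to clear the scatter.

Going by these compounds, how far the true number lies past the limit stays open, so the full size of both steps is unknown. Also open, on these data alone, is whether an amine or a carboxylic acid at the same chain end, or a longer chain carrying the selenium group, would read differently on the shared core.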